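The source may hold more compounds than are shown below. What is called first, only, known or untested is meant among the compounds shown, and "the series" means these compounds.

Of the compounds shown here, two sharing one core have been tested in a functional assay for inhibition of sodium/hydrogen exchanger (Oryctolagus cuniculus); on this read-out higher numbers stand for weaker inhibition and lower numbers for stronger inhibition. Compound 1, `Cc1cc(Oc2cccc(Cl)c2)c(S(C)(=O)=O)cc1C(=O)N=C(N)N`, carries a 3-chlorophenoxy group, and in this assay compound 1 gives 21 nM. Compound 2, `Cc1cc(C#N)c(S(C)(=O)=O)cc1C(=O)N=C(N)N`, carries a cyano group in that place, and in this assay compound 2 gives 70 nM, the higher of the two numbers seen so far. Among the measured compounds shown here, the only measured step is a 3.3-fold higher number from compound 1 to compound 2 (0.52 log units; beyond the scatter). Compound 3, `Cc1cc(Oc2cncc(Cl)c2)c(S(C)(=O)=O)cc1C(=O)N=C(N)N`, differs from compound 2 by (5-chloropyridin-3-yl)oxy in place of cyano on an aromatic carbon. The entering group resembles the 3-chlorophenoxy of compound 1, so the measured step bears directly on this change, simply run the other way: the expected step is a 2.8-fold lower number from compound 2 to compound 3 (0.45 log units; beyond the scatter), because compound 1 gave 21 nM. Compound 3 is therefore expected to give 25 nM, with a range from 8 nM to 80 nM.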

Compound 3, half-maximal inhibitory concentration: 14 nM
Estimate against measurement, compound 3: 1.8-fold (0.25 log units) above, within the range that was stated.
By their numbers in this assay, from the lowest: compounds 3 and 1 (each within the scatter of the next); then compound 2.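

With a second ring-bearing ether at this aromatic carbon, this assay gives a 5.0-fold lower number from compound 2 to compound 3 (0.70 log units; beyond the scatter), so both ether groups shown, the 3-chlorophenoxy and the (5-chloropyridin-3-yl)oxy, read lower than cyano. Exchanging the carbon-only ring for a pyridine ring, with the chlorine kept, gives a 1.5-fold lower number from compound 1 to compound 3 (0.18 log units; within the scatter), which lies within the scatter, so this assay does not separate these two groups. No measurement on hand explains either result.

The compounds shown cannot tell whether the lower numbers follow from the ether oxygen, the ring or the chlorine, and a plain phenoxy, a small methoxy or a directly attached phenyl would each separate these parts. Going by these compounds, how an amine or a carboxylic acid at this position would read also remains open.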